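This account rests on a few compounds, and the source may have more. Where it says the series, first, only, none or still open, it means among the compounds named here.

Of the compounds shown here, two have been measured in a functional assay on SW-620 cells (Homo sapiens) for antiproliferative activity, read by MTT assay, with a stated time of 48 h; a higher number here means a weaker inhibitor, a lower number a stronger inhibitor. Compound 1 `Cc1cc(C(=O)N2CCC3(CC2)CC(=O)N(c2ccc(C(F)(F)F)cc2)C3)cc2cn[nH]c12` is reported at > 10000 nM, which is a limit and not a number. Among the compounds with values here, compound 2 `O=C(c1ccc2[nH]c(-c3ccccc3)nc2c1)N1CCC2(CC1)CC(=O)N(c1ccc(C(F)(F)F)cc1)C2` gives 2050 nM, the only actual number so far, so it has no measured value to be ranked against. Compound 3 `O=C(c1ccc2[nH]c(-c3ccco3)nc2c1)N1CCC2(CC1)CC(=O)N(c1ccc(C(F)(F)F)cc1)C2` departs from compound 2 at a single place: furan-2-yl in place of phenyl on an aromatic carbon. Furan-2-yl stands in place of phenyl on an aromatic carbon of a five-membered aromatic ring with 2 nitrogen, between two ring nitrogen atoms. Within the data shown here, no measured pair shows what a single change does in this assay, so compound 2, at 2050 nM, is the only reference. Little change is expected, with no step beyond the scatter and a slight lean towards weaker inhibition. The expected 1.2-fold higher number from compound 2 to compound 3 (0.09 log units; within the scatter) is small. For compound 3 the estimated value is 2500 nM, with an expected range from 800 nM to 8000 nM.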

Compound 3, half-maximal inhibitory concentration: 3260 nM
Beside the measured number, compound 3's estimate is 1.3-fold (0.12 log units) below it; the measured number falls inside the stated range.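

In this assay, within the data shown here, the first single change that can be read, furan-2-yl in place of phenyl on an aromatic carbon between two ring nitrogen atoms, gives a 1.6-fold higher number from compound 2 to compound 3 (0.20 log units; within the scatter). At this position, then, a five-membered aromatic ring with 1 hetero atom and 1 hydrogen-bond acceptor can stand in place of a six-membered aromatic ring of carbon only, with no shift beyond the scatter. Nothing in the data shown accounts for the size of this step.

The compounds shown carry only aromatic rings at this position, so they leave open what a methyl group, an amine or a carboxylic acid would do there. They also leave open whether a pyridine ring would behave like phenyl and furan-2-yl.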